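This account rests on a few compounds, and the source may have more. Where it says the series, first, only, none or still open, it means among the compounds named here.

Measured compounds in a functional assay on HCT-116 cells (Homo sapiens) for cytotoxicity, read by MTT assay, with a stated time of 24 h; on this read-out lower numbers stand for stronger inhibition and higher numbers for weaker inhibition:
compound 1 `COc1cccc(-n2cc(COc3c(/C=C\C(=O)O)ccc(OC)c3CC=C(C)C)nn2)c1` gives 21600 nM
compound 2 `COc1ccc(-n2cc(COc3c(/C=C\C(=O)O)ccc(OC)c3CC=C(C)C)nn2)cc1` gives 8700 nM

Compound 2 holds the lowest of the two numbers in this assay; its nearest neighbour is compound 1, and the step of a 2.5-fold lower number from compound 1 to compound 2 (0.39 log units; beyond the scatter) lies beyond the scatter. Compound 3 `COc1ccc(/C=C\C(=O)O)c(OCc2cn(-c3ccc(C#N)cc3)nn2)c1CC=C(C)C` is not yet measured. It differs from compound 2 by cyano in place of methoxy on an aromatic carbon. Within the data shown here, the only step recorded, a 2.5-fold lower number from compound 1 to compound 2 (0.39 log units; beyond the scatter), concerns the position of the methoxy on the aromatic nitrogen substituent, not an exchange of the group itself, so it bears on the present change only loosely: it shows that alteration at this phenyl can move the number modestly. For compound 3 no step beyond the scatter is expected in this assay, and the estimate is 7000 nM with a range of 2500 nM to 20000 nM, which corresponds to an expected step of a 1.2-fold lower number from compound 2 to compound 3 (0.09 log units; within the scatter).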

Compound 3, half-maximal inhibitory concentration: 21000 nM
Estimate against measurement, compound 3: 3.0-fold (0.48 log units) below; the whole stated range lies below it.
By their numbers in this assay, from the lowest: compound 2; then compounds 3 and 1 (each within the scatter of the next).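

In this assay, exchanging the group itself at this place, 4-methoxyphenyl to 4-cyanophenyl, gives a 2.4-fold higher number from compound 2 to compound 3 (0.38 log units; beyond the scatter), so the number responds to the identity of the substituent and not only to where a methoxy sits. The comparison with the 3-methoxyphenyl analogue gives a 1.0-fold lower number from compound 1 to compound 3 (0.01 log units; within the scatter), which leaves compound 2, with its 4-methoxyphenyl, as the only one of the three set apart by a step beyond the scatter. No measured property on hand accounts for these differences.

Going by these compounds, whether a hydroxyl or an amine in the same place would give a number nearer compound 2 or nearer compound 3 remains open. On these data alone, only the aryl group varies across these compounds, so the contribution of the rest of the shared core also remains open.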